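Swapping the Group on the Ring Nitrogen

A few compounds are considered here, and "the series" means these few. Any claim that something is new, unique, unknown or untested is made for them only; others in the source may bear on it.

Of the compounds shown here, two built on a shared core have been measured so far. Compound 1 `CO[C@@H]1CC=C2NN(c3cc(Cl)cc(Cl)c3)C(=O)CC[C@]2(c2ccccc2)O1` was tested in a functional assay on SK-N-SH cells (Homo sapiens) for cytotoxicity, read by sulforhodamine B assay, with a stated time of 48 h (a higher number here means a weaker inhibitor, a lower number a stronger inhibitor), where compound 1 gives 7110 nM. Compound 2 `CO[C@@H]1CC=C2N(c3ccc(C)cc3)C(=O)C[C@]2(c2ccccc2)O1` carries a 4-methylphenyl group on an amide-type nitrogen in a ring, and in this assay compound 2 gives 3500 nM. Of these two numbers, compound 2 has the lower one, and the gap to compound 1 lies beyond the usual scatter of repeated measurements, so compound 2 counts as the stronger inhibitor of the pair.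

Compound 3 `CO[C@@H]1CC=C2N(c3ccccn3)C(=O)C[C@]2(c2ccccc2)O1` has not yet been measured. It differs from compound 2 in a single place: pyridin-2-yl in place of 4-methylphenyl on an amide-type nitrogen in a ring. Among the compounds with values here, no step between two measured compounds that differ in only one place is available to guide this change, so the expectation rests on the modest size of the swap alone. Compound 3 is expected to land close to compound 2, with the estimated step of a 1.4-fold higher number from compound 2 to compound 3 (0.15 log units; within the scatter) small and, if anything, toward a slightly higher number, near the edge of the scatter. The estimate for compound 3 is 5000 nM, with a range from 1800 nM to 14000 nM.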

Compound 3, half-maximal inhibitory concentration: 5100 nM
Compound 3: middle estimate off by 1.0-fold (0.01 log units), on the low side; the range from low to high includes it.
By their numbers in this assay, from the lowest: compounds 2, 3 and 1 (each within the scatter of the next, the first and the last beyond it).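

Within the data shown here, this is the first step that changes only the group on the amide-type nitrogen in a ring, and in this assay it reads a 1.5-fold higher number from compound 2 to compound 3 (0.16 log units; within the scatter), so the two compounds cannot be told apart. At this position, therefore, 4-methylphenyl can give way to pyridin-2-yl, an aromatic ring with 1 hetero atom and 1 hydrogen-bond acceptor, with no change in the number that stands out from the scatter of repeated measurements. Nothing measured here explains why these two groups read alike.

The swap also changes two things at once, removing the methyl group and placing a nitrogen in the ring, so the compounds shown cannot say what each does alone; plain phenyl or 4-methylpyridin-2-yl on the same nitrogen would separate the two. Going by these compounds, it also remains open whether this position accepts groups of a different kind, such as a phenyl ring carrying a carboxylic acid or an amine, or a longer chain ending in such a ring.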